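Phenyl in Place of Isopentyl on a Shared Core

This account rests on a few compounds, and the source may have more. Where it says the series, first, only, none or still open, it means among the compounds named here.

Of the compounds shown here, three built on one core have been tested in an in vitro functional assay on cells for agonist activity at Bombesin receptor subtype-3 (Mus musculus), read by luminescence and calcium flux; on this read-out lower numbers stand for an effect already at smaller amounts and higher numbers for an effect only at larger amounts of compound. Compound 1 `O=C(O)c1ccccc1-c1ccc(CCc2ncc(CC3CCCCC3)[nH]2)cc1` gives 7.3 nM. Compound 2 `O=C(O)c1ccccc1-c1ccc(CCc2ncc(CCC3CCCCC3)[nH]2)cc1` gives 33 nM. Compound 3 `CC(C)CCc1cnc(CCc2ccc(-c3ccccc3C(=O)O)cc2)[nH]1` gives 10 nM, which places it second highest of the three, near compound 1 and further from compound 2. Compound 4 `O=C(O)c1ccccc1-c1ccc(CCc2ncc(-c3ccccc3)[nH]2)cc1` differs from compound 3 by phenyl in place of isopentyl on an aromatic carbon. Going by the values given here, no measured step swaps a chain for an aromatic ring; the nearest guides are a 1.4-fold higher number from compound 1 to compound 3 (0.14 log units; within the scatter) and a 4.5-fold higher number from compound 1 to compound 2 (0.66 log units; beyond the scatter), where reshaping the chain moved the number little and lengthening it moved it modestly upward. A modest rise is therefore expected, a 2.0-fold higher number from compound 3 to compound 4 (0.30 log units; within the scatter). Compound 4 is estimated at 20 nM, with a range from 5 nM to 80 nM.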

Compound 4, half-maximal effective concentration: 872 nM
Beside the measured number, compound 4's estimate is 44-fold (1.64 log units) below it, and the stated range ends below it.
By their numbers in this assay, from the lowest: compounds 1 and 3 (each within the scatter of the next); then compound 2; then compound 4.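

Phenyl on this aromatic carbon gives far higher numbers than any of the saturated groups there, whether isopentyl (an 87-fold higher number from compound 3 to compound 4 (1.94 log units; beyond the scatter)), cyclohexylmethyl (a 120-fold higher number from compound 1 to compound 4 (2.08 log units; beyond the scatter)) or 2-cyclohexylethyl (a 26-fold higher number from compound 2 to compound 4 (1.42 log units; beyond the scatter)). The earlier compounds shown here showed this position accepting saturated chains of different shapes with modest shifts at most, whereas an aromatic ring bound directly to the aromatic carbon changes the number on a much larger scale. No measurement on hand explains this drop. Still open, going by these compounds, is whether the aromatic ring itself or the absence of a chain matters: cyclohexyl bound directly to that carbon, or benzyl, would separate the two.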